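Swapping the Piperazine Ring for a Morpholine in a Sulfonamide

This account rests on a few compounds, and the source may have more. Where it says the series, first, only, none or still open, it means among the compounds named here.

Measured so far:
- compound 1, `Cc1cc(C)c(S(=O)(=O)N2CCC(N3CCN(C)CC3)CC2)c(C)c1`: 1100 nM
- compound 2, `CCCOc1ccc(S(=O)(=O)N2CCC(N3CCC(C)CC3)CC2)cc1`: 452 nM

Of the compounds shown here, two have been tested in a functional assay on DLD-1 cells (Homo sapiens) for antiproliferative activity, read by CellTiter-Glo, with a stated time of 72 h; a lower number here means a stronger inhibitor, a higher number a weaker inhibitor. Compound 1 gives 1100 nM in this assay, which is the higher of the two numbers; compound 2 gives 452 nM, and the gap between them lies beyond the usual scatter, so compound 1 is the weaker inhibitor of the pair.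

Compound 3, `Cc1cc(C)c(S(=O)(=O)N2CCC(N3CCC(C)OC3)CC2)c(C)c1`, has not yet been measured. It differs from compound 1 in one place: a group of 7 heavy atoms (5 carbon, 1 nitrogen, 1 oxygen; one six-membered non-aromatic ring with 2 hetero atoms) in place of a group of 7 heavy atoms (5 carbon, 2 nitrogen; one six-membered non-aromatic ring with 2 hetero atoms), on a saturated ring carbon. The ring that leaves carries a second nitrogen bearing a methyl; the ring that enters carries an oxygen instead, with the methyl on a ring carbon.

Among the measured compounds shown here, no pair of measured compounds shows what such a swap does, so no step size can be read from the data. The change keeps the size of the group and its count of hydrogen-bond acceptors, so the expected step from compound 1 to compound 3 in this assay, a 1.2-fold higher number from compound 1 to compound 3 (0.07 log units; within the scatter), is small and within the scatter, with no direction favoured. Compound 3 is therefore estimated at 1300 nM in this assay, with a range from 400 nM to 4500 nM.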

Compound 3, half-maximal inhibitory concentration: 92 nM
Compound 3: the middle estimate sits 14-fold (1.15 log units) above what was measured; measured number outside the range, below it.
By their numbers in this assay, from the lowest: compound 3; then compound 2; then compound 1.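

In this assay, replacing the 4-methylpiperazin-1-yl group with the ring that carries an oxygen gives a 12-fold lower number from compound 1 to compound 3 (1.08 log units; beyond the scatter) at this place on the shared core, a saturated ring carbon. The two groups match in heavy-atom count, ring size, hydrogen-bond donors, hydrogen-bond acceptors and net charge, so these counts alone do not tell how far the number will move: here, a change in ring atoms and in where the methyl sits goes with a large step. No measurement available here accounts for the size of this step. This single pair therefore shows that the position responds strongly to the make-up of the ring, even when the counted features stay the same.

Because the oxygen and the methyl change together, the compounds shown cannot separate what each contributes to the step. Going by these compounds, it also remains open how the number would respond on the same core to a plain morpholine ring, to an unsubstituted piperidine ring or to an open-chain dimethylamino group at this place.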